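Phenyl for Methyl on Two Fused Cores

The source may report more compounds than this note shows. Statements on the series, on what has been measured and on what is new or still open speak of the compounds shown alone.

Measured so far in a functional assay for inhibition, with Homo sapiens as the target; a higher number here means a weaker inhibitor, a lower number a stronger inhibitor:
Compound 1 `CCCc1nc(C)c2c(-c3ccccc3)nnc(O)n12` gives > 48000 nM, which is a limit of the assay and not a number.
Compound 2 `CCCc1nc(C)c2c(C)nnc(O)n12` gives 14000 nM.
Compound 3 `C=CCSc1nncc2c(C)nc(C)n12` gives 59000 nM.

Compound 1 arises from compound 2 by phenyl in place of methyl on an aromatic carbon. In this assay that change gave an at least 3.4-fold higher number from compound 2 to compound 1 (0.53 log units; beyond the scatter), a weakening, with the upper value resting on (the limit of > 48000 nM in this assay, at which 1 of the 3 values shown sits).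

Compound 4 `C=CCSc1nncc2c(C)nc(-c3ccccc3)n12` has not been measured. It arises from compound 3 by phenyl in place of methyl on an aromatic carbon. This is the same kind of change, not the same: here it sits on a five-membered aromatic ring with 2 nitrogen, between two ring nitrogen atoms, whereas in compound 1 it sits on a six-membered aromatic ring with 3 nitrogen, next to the ring nitrogen and para to a hydroxy group. The difference between the cores of compound 3 and compound 2 is not broken down here.

Since compound 3 already stands at the higher of the two numbers, the expected step from compound 3 to compound 4 in this assay is a further weakening, a 2.5-fold higher number from compound 3 to compound 4 (0.41 log units; beyond the scatter), resting on an at least 3.4-fold higher number from compound 2 to compound 1 (0.53 log units; beyond the scatter). For compound 4 the estimate is 150000 nM, within 50000 nM to 500000 nM, with a limit rather than a number quite likely.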

Compound 4, half-maximal inhibitory concentration: > 48000 nM
Compound 4 was reported as a limit; the forecaster's own chance of this, stated with the estimate: 60%; the middle value does not contradict the limit.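

Going by these compounds alone, compound 4 gives > 48000 nM in this assay, which is a limit of the assay and not a number, so no step from compound 3 to compound 4 can be read. The compounds shown leave open how large the change from methyl to phenyl is on the core of compound 3.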